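The source may report more compounds than this note shows. Statements on the series, on what has been measured and on what is new or still open speak of the compounds shown alone.

Measured so far in a functional assay, with a stated time of 150 min, tested at 25 ug/mL; a higher number here means a stronger effect of the compound at the concentration tested, a lower number a weaker effect:
- compound 1 `COC(=O)c1c(Nc2ccccc2)sc(C(=O)c2ccc(OC)cc2)c1C`: 36.9%
- compound 2 `COC(=O)c1c(Nc2ccc(OC)cc2)sc(C(=O)c2ccc(OC)cc2)c1C`: 15.5%
- compound 3 `COC(=O)c1c(Nc2ccc(Cl)cc2)sc(C(=O)c2ccc(OC)cc2)c1C`: "not active" (no number reported)

Compound 1 gives the higher of the two numbers reported. Compound 2 sits below it, the step being a number 21.4 percentage points lower from compound 1 to compound 2 (beyond the scatter). Compound 3 was reported without a number, so it cannot be placed on this scale.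

The unmeasured compound 4 `COc1ccc(C(=O)c2sc(Nc3ccccc3)c(C(=O)O)c2C)cc1` keeps the whole shared core of compound 1 and differs from it at one spot only: hydrogen in place of methyl on an oxygen next to a carbonyl group.

Among the compounds with values here, none of the measured steps touches this position. Within the data shown here, the one step that is known, from compound 1 to compound 2, changes a group on the aromatic ring of the aniline part, not the ester, so it says nothing about what the change to the carboxy group will do. The expectation for compound 4 therefore rests on compound 1 alone and carries a wide range. The step from compound 1 to compound 4 is expected to be a number 11.9 percentage points lower from compound 1 to compound 4 (beyond the scatter), a modest fall. Compound 4 is estimated to give 25% in this assay, somewhere between 5% and 50%.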

Compound 4, a percentage reported as activity, at one concentration (the size of the read-out at that concentration, not a potency): 52.6%
The estimate for compound 4 lay 27.6 percentage points below the measured number; the whole stated range lies below it.
By their numbers in this assay, from the lowest: compound 2; then compound 1; then compound 4.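

In this assay, replacing the methoxycarbonyl group with a carboxy group gives a number 15.7 percentage points higher from compound 1 to compound 4 (beyond the scatter). Within the data shown here, this is the first sign that the read-out responds to a change at this position, and that the methyl on this oxygen is not needed for the effect in the core of compound 1: with hydrogen in its place, the number goes up rather than down. No measurement at hand explains the rise.

Going by these compounds, it remains open whether an ethyl ester, a primary amide or a nitrile in this position would raise the number, lower it or leave it unchanged. On these data alone, it is also open whether the same change from methyl to hydrogen would raise the number of compound 2 or give a number for compound 3.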